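This account rests on a few compounds, and the source may have more. Where it says the series, first, only, none or still open, it means among the compounds named here.

Compound 1 `CC(C)(C)C1=NN(c2cccc(F)c2)C(c2ccc(O)cc2)C1`, in an assay on isolated protein for inhibition of protein kinase C zeta type (Homo sapiens), with a stated time of 4 min (a lower number here means a stronger inhibitor, a higher number a weaker inhibitor), compound 1 gives 2200 nM.
Compound 2 `Cc1cccc(N2N=C(C(C)(C)C)CC2c2ccc(O)cc2)c1`, in this assay compound 2 gives 3500 nM.
Compound 3 `CC(C)(C)C1=NN(c2c(Cl)cccc2Cl)C(c2ccc(O)cc2)C1`, in this assay compound 3 gives "not determined" (no result reported).

Compound 3 has no number in this assay, so there is nothing to place it against compounds 1 and 2. Compound 4 `CC(C)(C)C1=NN(c2ccc(F)c(Cl)c2)C(c2ccc(O)cc2)C1` differs from compound 3 in one place: 3-chloro-4-fluorophenyl in place of 2,6-dichlorophenyl on an amine nitrogen in a ring. Among the compounds with values here, the only measured step that touches the same aryl group is a 1.6-fold higher number from compound 1 to compound 2 (0.20 log units; within the scatter), a swap of one ring substituent that stayed within the scatter. Within the data shown here, no measured step covers a change in the count or position of halogens on this ring. Compound 4 is therefore expected to land near compounds 1 and 2, at an estimated 2500 nM, with a range from 700 nM to 9000 nM.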

Compound 4, half-maximal inhibitory concentration: 900 nM
The estimate for compound 4 lay 2.8-fold (0.44 log units) above the measured number; the measured number falls inside the stated range.
By their numbers in this assay, from the lowest: compound 4; then compounds 1 and 2 (each within the scatter of the next).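

Changing the aryl group on the ring nitrogen can move the number beyond the scatter in this assay: the 3-chloro-4-fluorophenyl group gives a 2.4-fold lower number from compound 1 to compound 4 (0.39 log units; beyond the scatter) and a 3.9-fold lower number from compound 2 to compound 4 (0.59 log units; beyond the scatter), unlike the earlier swap of one ring substituent. The change from 2,6-dichlorophenyl cannot be read, as compound 3 has no number. Nothing measured here explains the gain.

Which of the two halogens in compound 4 accounts for the steps remains open. So does whether an amine or a carboxylic acid on this aryl ring would keep the number as low.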